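Solubility notes on an amide substituent change

The compounds below may be only part of what the source reports. "The series", "measured", "known", "first", "only" and "open" are said of these compounds alone.

Measured so far:
Compound 1 `CS(=O)(=O)c1ccc(OCCCC2CC3(CCN(C(=O)OC4CCCC4)CC3)C2)cc1F`: < 0.14 ug/mL
Compound 2 `CC(C)OC(=O)N1CCC2(CC1)CC(CCCOc1ccc(C(=O)NC3CC3)c(F)c1)C2`: 0.21 ug/mL

Going by the values given here, in a physicochemical assay for solubility, read by HPLC, in phosphate buffer, with a stated time of 24 h, at pH 6.8 (on this read-out higher numbers stand for higher solubility and lower numbers for lower solubility), compound 2 gives 0.21 ug/mL, the only number among the values shown. Compound 1 gives < 0.14 ug/mL, which is a limit of the assay rather than a number. Compound 3 `CC(C)OC(=O)N1CCC2(CC1)CC(CCCOc1ccc(C(=O)NCC(N)=O)c(F)c1)C2` differs from compound 2 by carbamoylmethyl in place of cyclopropyl on an amide-type nitrogen. Among the compounds with values here, no step between measured compounds is available to set the size of this change, so the expectation rests on the structural change alone. A rise beyond the usual scatter is expected, estimated as a 7.1-fold higher number from compound 2 to compound 3 (0.85 log units; beyond the scatter). For compound 3 the estimate is 1.5 ug/mL, with a range from 0.3 ug/mL to 8 ug/mL.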

Compound 3, solubility: 1.77 ug/mL
Compound 3: middle estimate off by 1.2-fold (0.07 log units), on the low side; the measured number falls inside the stated range.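

Going by these compounds alone, on the amide-type nitrogen, an 8.4-fold higher number from compound 2 to compound 3 (0.93 log units; beyond the scatter) is the only readable step in this assay and lies beyond the scatter. This position therefore responds to carbamoylmethyl in place of cyclopropyl. Within the data shown here, compound 1 gives < 0.14 ug/mL, a limit of the assay and not a number, and it adds no step: the limit of < 0.14 ug/mL in this assay, at which 1 of the 3 values shown sits.

From the compounds shown here alone, whether the rise follows from the carbamoyl part of carbamoylmethyl or from the loss of the cyclopropyl ring stays open on this single pair. Going by these compounds, how an amine or a carboxylic acid on the same chain would read in this assay also stays open.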